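The compounds below may be only part of what the source reports. "The series", "measured", "known", "first", "only" and "open" are said of these compounds alone.

Two dienamides have been run in an assay for inhibition of Polyunsaturated fatty acid 5-lipoxygenase (Homo sapiens), read by spectrophotometry, tested at 20 uM (a higher number here means more inhibition at the concentration tested (going by the name of the read-out), a lower number less inhibition), so far. Compound 1 `CN(C)c1ccc(/C=C/C=C/C(=O)N2CCCCC2)cc1` gives 13.4%, the lowest of the two numbers. Compound 2 `COc1cc(OC)c(/C=C/C=C/C(=O)N2CCCCC2)c(OC)c1` gives 77.1%, a gap beyond the usual scatter. Within the data shown here, no pair differing in a single place has yet been measured, so the step to compound 3 `O=C(/C=C/C=C/c1ccc(OC2CCCC2)cc1)N1CCCCC1` rests on the structural change alone: cyclopentyloxy in place of dimethylamino on an aromatic carbon. An increase from compound 1 is expected in this assay, a number 31.6 percentage points higher from compound 1 to compound 3 (beyond the scatter), because compound 2 with its alkoxy substituents reaches 77.1%. Compound 3 is estimated to give 45% in this assay, with a range from 15% to 75%.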

Compound 3, a percentage reported as inhibition, at one concentration (the size of the read-out at that concentration, not a potency): 16.1%
The estimate for compound 3 lay 28.9 percentage points above the measured number; low and high end bracket the measured number.
By their numbers in this assay, from the lowest: compounds 1 and 3 (each within the scatter of the next); then compound 2.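

For this assay, cyclopentyloxy in place of dimethylamino on an aromatic carbon para to a large group gives a number 2.7 percentage points higher from compound 1 to compound 3 (within the scatter) and so does not separate the two compounds. At this position, the exchange of one nitrogen-linked group for this larger oxygen-linked group with its five-membered ring leaves the read-out unchanged within the scatter. Nothing available explains this result.

Still open, from the compounds shown here alone, is whether a smaller group on the same carbon, such as ethoxy, hydroxyl or a carboxylic acid, would give a different number. Going by these compounds, whether cyclopentyloxy and dimethylamino would also match on another core remains open too.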